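Closing the Carbamate into an Oxazolidinone Ring

The source may hold more compounds than are shown below. What is called first, only, known or untested is meant among the compounds shown, and "the series" means these compounds.

Compounds measured so far:
compound 1 `Nc1nc(-c2nn(Cc3ccccc3F)c3ncccc23)nc(N)c1NC(=O)OCC(F)(F)F` — 0.2 uM
compound 2 `Nc1nc(-c2nn(Cc3ccccc3F)c3ncccc23)nc(N)c1NC(=O)OCC1CC1` — 0.2 uM

In an assay on cells for activation of Guanylate cyclase soluble subunit alpha-1 (Rattus norvegicus), read by cGMP accumulation and immunoassay, with a stated time of 10 min (a lower number here means that less compound is needed, a higher number that more compound is needed for the effect), compound 1 gives 0.2 uM, and compound 2 gives 0.2 uM. The step of no change at the digits printed from compound 1 to compound 2 (within the scatter) shows that exchanging the group at the end of the open chain left the minimum effective concentration unchanged, so compound 2 stands level with compound 1.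

Compound 3 `Nc1nc(-c2nn(Cc3ccccc3F)c3ncccc23)nc(N)c1N1C[C@@H](C(F)(F)F)OC1=O` alters the same side of the shared core more deeply: 2-oxo-5-(trifluoromethyl)-1,3-oxazolidin-3-yl in place of (cyclopropylmethoxycarbonyl)amino on an aromatic carbon. For the measured compounds named here, the only measured step concerns the far end of the chain and keeps the carbamate open; no measured pair covers closing the chain into a five-membered ring and removing the hydrogen-bond donor. That step therefore offers only weak guidance. Since the new ring keeps one double bond outside aromatic rings and two hydrogen-bond acceptors, a modest loss or no change beyond the scatter is expected, a 2.5-fold higher number from compound 2 to compound 3 (0.40 log units; beyond the scatter). Compound 3 is estimated at 0.5 uM, with a range from 0.1 uM to 3 uM.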

Compound 3, minimum effective concentration: 0.03 uM
The estimate for compound 3 lay 17-fold (1.22 log units) above the measured number; measured number outside the range, below it.
By their numbers in this assay, from the lowest: compound 3; then compounds 1 and 2 (each within the scatter of the next).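

In this assay, this position on the shared core proved sensitive after all: changing the end of the open chain had shifted nothing, whereas closing the chain into the ring gives a 6.7-fold lower number from compound 2 to compound 3 (0.82 log units; beyond the scatter). With trifluoromethyl present on both sides of the comparison, the step is the same size, a 6.7-fold lower number from compound 1 to compound 3 (0.82 log units; beyond the scatter), so the presence of trifluoromethyl alone does not account for the lower number. Nothing available here explains why the ring lowers the number.

The change brings in the ring, removes the hydrogen-bond donor and adds a defined stereocentre all at once, so the compounds shown cannot say which of these matters. The same ring with methyl in place of trifluoromethyl, or with the opposite configuration at the stereocentre, would begin to separate these features.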